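From compound 3 to compound 4: exchanging the aryl group

This account rests on a few compounds, and the source may have more. Where it says the series, first, only, none or still open, it means among the compounds named here.

In an ADME assay for permeability, using PAMPA, with a stated time of 30 min, at pH 7.4 (a higher number here means that the compound crosses the layer faster, a lower number that the compound crosses the layer more slowly), compound 3 `CN(C)c1cccc(Oc2ccc3c(NCCCNCc4ccco4)ccnc3c2)c1` gives 317 10^-6 cm/s and stands level with compound 2 `COc1cccc(Oc2ccc3c(NCCCNCc4ccco4)ccnc3c2)c1` at 317 10^-6 cm/s and within the scatter of compound 1 `Fc1ccc(-c2ccc3c(NCCCNCc4ccco4)ccnc3c2)cc1` at 237 10^-6 cm/s in this small set. Compound 4 `CC(C)(C)c1ccc(-c2ccc3c(NCCCNCc4ccco4)ccnc3c2)cc1` carries 4-(tert-butyl)phenyl in place of 3-(dimethylamino)phenoxy on an aromatic carbon on the shared core. For the measured compounds named here, three measured steps bear on this: a 1.3-fold higher number from compound 1 to compound 3 (0.13 log units; within the scatter) and a 1.3-fold higher number from compound 1 to compound 2 (0.13 log units; within the scatter) for the exchange of 4-fluorophenyl, and no change at the digits printed from compound 2 to compound 3 (within the scatter) for the change on the phenoxy group. Going by the values given here, no measured compound carries the tert-butyl group, so the range stays wide. With all three steps inside the scatter, none beyond it is expected in this assay and the estimated change is a 1.2-fold lower number from compound 3 to compound 4 (0.07 log units; within the scatter) for now. For compound 4 the estimated value is 270 10^-6 cm/s (expected range 150 10^-6 cm/s to 420 10^-6 cm/s).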

Compound 4, apparent permeability: 237 10^-6 cm/s
The estimate for compound 4 lay 1.1-fold (0.06 log units) above the measured number; measured number inside the range.
By their numbers in this assay, from the lowest: compounds 1, 4, 2 and 3 (each within the scatter of the next).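

In this assay, 4-(tert-butyl)phenyl at this aromatic carbon reads the same within the scatter as either aryl ether it replaces, 3-(dimethylamino)phenoxy (a 1.3-fold lower number from compound 3 to compound 4 (0.13 log units; within the scatter)) and 3-methoxyphenoxy (a 1.3-fold lower number from compound 2 to compound 4 (0.13 log units; within the scatter)). tert-Butyl in place of fluoro on the phenyl group also leaves the number in place (no change at the digits printed from compound 1 to compound 4 (within the scatter)), so a group of carbon only stands with those carrying nitrogen, oxygen or fluorine. No supporting measurement bears on these steps. From the compounds shown here alone, whether a carboxylic acid or a primary amine on this aryl group would give a step beyond the scatter remains open.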